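The compounds below may be only part of what the source reports. "The series", "measured", "known", "first", "only" and "open" are said of these compounds alone.

Measured compounds in the series:

compound 1 `C[S+]([O-])c1c(F)c(N)c2c(=O)cc(-c3ccc(N)c(F)c3)oc2c1F` — 2500 nM
compound 2 `Nc1ccc(-c2cc(=O)c3c(N)c(F)c(C(=O)O)c(F)c3o2)cc1F` — the value reported is a limit of the assay, > 10000 nM
compound 3 `CCCCCCCCCC(=O)OCc1c(F)c(N)c2c(=O)cc(-c3ccc(N)c(F)c3)oc2c1F` — 100 nM

In a functional assay on MCF7 cells (Homo sapiens) for cytotoxicity, read by neutral red uptake, with a stated time of 3 days (a higher number here means a weaker inhibitor, a lower number a stronger inhibitor), compound 1 gives 2500 nM. For compound 2 the assay returns only a limit, > 10000 nM. Compound 3 stands lowest of the two numbers shown; the nearest number, that of compound 1, is a higher one, a gap beyond the scatter. Among the compounds with values here, the only measured step, an at least 4.0-fold higher number from compound 1 to compound 2 (0.60 log units; beyond the scatter), concerns a different change on the shared core and is bounded by the limit of > 10000 nM in this assay, at which 1 of the 3 values shown sits; it shows only that the group at that position moves the number, and does not cover the change at hand.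

Compound 4 `COCc1c(F)c(N)c2c(=O)cc(-c3ccc(N)c(F)c3)oc2c1F` differs from compound 3 by methyl in place of nonylcarbonyl on an oxygen on a saturated carbon. Within the data shown here, with no measured step covering this change, the expectation rests on compound 3 at 100 nM and on compound 1 at 2500 nM: a number for compound 4 in this assay is expected between those two, the step of an 8.0-fold higher number from compound 3 to compound 4 (0.90 log units; beyond the scatter) being an increase beyond the scatter. Compound 4 is estimated at 800 nM, within 200 nM to 4000 nM.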

Compound 4, half-maximal inhibitory concentration: 46 nM
Estimate against measurement, compound 4: 17-fold (1.24 log units) above, outside the stated range (below it).
By their numbers in this assay, from the lowest: compound 4; then compound 3; then compound 1. At a limit, above all of these: compound 2.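

In this assay the long nonylcarbonyl is not required for a low number, with a 2.2-fold lower number from compound 3 to compound 4 (0.34 log units; beyond the scatter) when methyl takes its place on an oxygen on a saturated carbon. On the aromatic carbon, methoxymethyl stands well clear of both other groups, with a 54-fold lower number from compound 1 to compound 4 (1.74 log units; beyond the scatter) and an at least 210-fold lower number from compound 2 to compound 4 (2.33 log units; beyond the scatter) in the comparison with carboxy. The second of these steps is only a bound, since compound 2 stands at a limit: the limit of > 10000 nM in this assay, at which 1 of the 4 values shown sits.

The compounds shown leave open how the number runs with a free hydroxyl on that saturated carbon, or with a shorter acyl group such as acetyl in place of nonylcarbonyl. They also leave open where an amide or an amine on the aromatic carbon would fall in this series.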